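Permeability notes on the 4-aminoquinoline series: compound 3

This account rests on a few compounds, and the source may have more. Where it says the series, first, only, none or still open, it means among the compounds named here.

Among the compounds with values here, compound 2 `COc1ccc(F)cc1CNCCCNc1ccnc2cc(Cc3ccccc3)ccc12` stands lowest of the two numbers measured so far; in an ADME assay for permeability, using PAMPA, with a stated time of 30 min, at pH 7.4 (a higher number here means that the compound crosses the layer faster, a lower number that the compound crosses the layer more slowly), compound 2 gives 23 10^-6 cm/s. Compound 1 `COc1cccc(Oc2ccc3c(NCCCNCc4cc(F)ccc4OC)ccnc3c2)c1` gives 317 10^-6 cm/s in this assay, and the step of a 14-fold lower number from compound 1 to compound 2 (1.14 log units; beyond the scatter) is the only one measured. Compound 3 `COc1ccc(F)cc1CNCCCNc1ccnc2cc(-c3ccc(C(C)(C)C)cc3)ccc12` carries 4-(tert-butyl)phenyl in place of benzyl on an aromatic carbon. Within the data shown here, that step is not directly covered by the one measured step, which concerns a different pair of groups at the same place; it gives no clear direction for this assay. The expected change is therefore modest, a 2.0-fold higher number from compound 2 to compound 3 (0.29 log units; within the scatter), and compound 3 is estimated at 45 10^-6 cm/s, with a range from 12 10^-6 cm/s to 170 10^-6 cm/s.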

Compound 3, apparent permeability: 237 10^-6 cm/s
Beside the measured number, compound 3's estimate is 5.3-fold (0.72 log units) below it, and the stated range ends below it.
By their numbers in this assay, from the lowest: compound 2; then compounds 3 and 1 (each within the scatter of the next).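

The step of a 10-fold higher number from compound 2 to compound 3 (1.01 log units; beyond the scatter) shows that this aromatic carbon can carry a large change between two carbon-only groups, each with no hydrogen-bond donors, no acceptors and no net charge. Within the data shown here, the step of a 1.3-fold lower number from compound 1 to compound 3 (0.13 log units; within the scatter) puts 4-(tert-butyl)phenyl and 3-methoxyphenoxy level in this assay and leaves benzyl as the one group apart from them. Nothing measured here explains that difference.

Still open, as far as these compounds go, is whether plain phenyl at this place would read with benzyl or with 4-(tert-butyl)phenyl. An amine or a carboxylic acid at the same carbon also remains an open case.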